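The source may report more compounds than this note shows. Statements on the series, on what has been measured and on what is new or still open speak of the compounds shown alone.

Measured compounds in a functional assay on MCF7 cells (Homo sapiens) for cytotoxicity, read by MTT assay, with a stated time of 48 h; on this read-out higher numbers stand for weaker inhibition and lower numbers for stronger inhibition:
Compound 1 `COc1cc(-c2nnc3n2NC(c2ccco2)C(C(=O)C2CC2)S3)cc(OC)c1OC` gives > 100000 nM, a limit of the assay and not a number.
Compound 2 `COc1cc(-c2nnc3n2NC(c2ccco2)C(C(=O)c2cccs2)S3)cc(OC)c1OC` gives > 100000 nM, likewise a limit.
Compound 3 `COc1cc(-c2nnc3n2NC(c2ccco2)C(C(=O)c2ccccc2C)S3)cc(OC)c1OC` gives 69900 nM.

Compound 1 therefore stands at the limit, with one other compound sharing it (the limit of > 100000 nM in this assay, at which 2 of the 3 values shown sit). The step to compound 2, a step that the two limits leave unreadable from compound 1 to compound 2, is unreadable between two limits. The step to compound 3, an at least 1.4-fold lower number from compound 1 to compound 3 (0.15 log units; that floor lies within the scatter), and the step of an at least 1.4-fold lower number from compound 2 to compound 3 (0.15 log units; that floor lies within the scatter) show only a floor that lies within the scatter. Compound 4 `COc1cc(-c2nnc3n2NC(c2ccco2)C(C(=O)c2cccc4ccccc24)S3)cc(OC)c1OC` differs from compound 1 by naphthalen-1-yl in place of cyclopropyl on a carbonyl carbon. As an aryl group on the carbonyl carbon resembles the change to compound 3, compound 4 is expected to give about 50000 nM, between 15000 nM and 200000 nM, a step of an at least 2.0-fold lower number from compound 1 to compound 4 (0.30 log units; that floor lies within the scatter).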

Compound 4, half-maximal inhibitory concentration: > 100000 nM
Compound 4: a limit, no number (the forecaster's own chance of this, stated with the estimate: 40%); at least 2.0-fold (0.30 log units) between middle value and limit.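

Compound 4 gives a limit and not a number in this assay, so the larger naphthalen-1-yl group on the carbonyl carbon brings no readable value: the limit of > 100000 nM in this assay, at which 3 of the 4 values shown sit. The steps that end or start between two limits cannot be read. Naphthalen-1-yl in place of 2-methylphenyl gives an at least 1.4-fold higher number from compound 3 to compound 4 (0.15 log units; that floor lies within the scatter), so no order is established, and an aryl group at this place does not by itself give a readable gain.

On these data alone, whether a dimethylamino group or a carboxylic acid on the phenyl ring at this carbonyl carbon would give a value clear of the limit stays open.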